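Moving the Ring Nitrogen in the Amide Substituent

The source may hold more compounds than are shown below. What is called first, only, known or untested is meant among the compounds shown, and "the series" means these compounds.

Compound 1, `Cc1cccc(F)c1N(C)C(=O)c1ccc(-c2ccc(O)cc2)o1`, gives 310 nM in an assay on cytosol from placenta for inhibition of 17-beta-hydroxysteroid dehydrogenase type 1 (Homo sapiens), read by HPLC, with a stated time of 10 min, in the presence of a further agent that is not named here; a lower number here means a stronger inhibitor, a higher number a weaker inhibitor. Compound 2, `Cc1cc(F)ccc1N(C)C(=O)c1ccc(-c2ccc(O)cc2)o1`, gives 23 nM. Compound 3, `Cc1cccnc1N(C)C(=O)c1ccc(-c2ccc(O)cc2)o1`, gives 3300 nM.

Compound 3 stands highest of the three numbers in this assay; its nearest neighbour is compound 1, with an 11-fold higher number from compound 1 to compound 3 (1.03 log units; beyond the scatter), and its furthest is compound 2, with a 140-fold higher number from compound 2 to compound 3 (2.16 log units; beyond the scatter). The step from compound 3 to compound 4, `Cc1ccncc1N(C)C(=O)c1ccc(-c2ccc(O)cc2)o1`, is 4-methylpyridin-3-yl in place of 3-methylpyridin-2-yl on an amide-type nitrogen. Within the data shown here, no measured step matches this change: the two measured steps into compound 3 each exchange a fluoro-methylphenyl for a pyridinyl, and the one step between phenyl groups, a 13-fold lower number from compound 1 to compound 2 (1.13 log units; beyond the scatter), shows that rearranging the same substituents on a six-membered ring can shift the number by a large amount in either direction. Since both compound 1 and compound 2 lie below compound 3, a change that keeps the pyridinyl but moves its nitrogen and methyl is expected to leave the number nearer compound 3 than compound 2, with a modest drop plausible, so the expected step is a 2.2-fold lower number from compound 3 to compound 4 (0.34 log units; beyond the scatter). Compound 4 is therefore estimated at 1500 nM, within a range of 300 nM to 7500 nM.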

Compound 4, half-maximal inhibitory concentration: 260 nM
Beside the measured number, compound 4's estimate is 5.8-fold (0.76 log units) above it, and the stated range ends above it.
By their numbers in this assay, from the lowest: compound 2; then compounds 4 and 1 (each within the scatter of the next); then compound 3.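

In this assay, the placement of the ring nitrogen and the methyl within the pyridinyl group on the amide-type nitrogen carries a large effect of its own: the two groups have the same atoms, joined differently, yet 4-methylpyridin-3-yl in place of 3-methylpyridin-2-yl gives a 13-fold lower number from compound 3 to compound 4 (1.10 log units; beyond the scatter) for this change. A pyridinyl group at this place is thus not tied to the high number of compound 3, as a 1.2-fold lower number from compound 1 to compound 4 (0.08 log units; within the scatter) leaves compound 4 and compound 1 indistinguishable in this assay, although a fluoro-methylphenyl group and a pyridinyl group are being exchanged. The 4-fluoro-2-methylphenyl group nonetheless remains apart from this pyridinyl group, with an 11-fold higher number from compound 2 to compound 4 (1.05 log units; beyond the scatter) on that exchange, and nothing available explains any of these differences.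

The compounds shown leave open how the number responds when the methyl of the 4-methylpyridin-3-yl group is replaced by a methoxy group, an amine or a fluorine. They also leave open whether a further arrangement, such as 2-methylpyridin-3-yl, would close the remaining gap to compound 2 or widen it.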